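This account rests on a few compounds, and the source may have more. Where it says the series, first, only, none or still open, it means among the compounds named here.

Compound 1 `CC(C)[C@@H](CO)n1cc(C(=O)O)c(=O)c2c(O)c(Cc3cccc(Cl)c3F)ccc21`: 125000 nM
Compound 2 `Cc1cccc(-n2cc(C(=O)O)c(=O)c3c(O)c(Cc4cccc(Cl)c4F)ccc32)c1`: 71600 nM
Compound 3 `O=C(O)c1cn(-c2ccc(Br)cc2)c2ccc(Cc3cccc(Cl)c3F)c(O)c2c1=O`: 85000 nM

In an ADME assay on C8166 cells (Homo sapiens) for cytotoxicity, read by MTT assay (on this read-out higher numbers stand for lower toxicity in this test and lower numbers for higher toxicity in this test), compound 1 gives the highest of the three numbers, yet its steps to the others, a 1.7-fold lower number from compound 1 to compound 2 (0.24 log units; within the scatter) and a 1.5-fold lower number from compound 1 to compound 3 (0.17 log units; within the scatter), both fall within the scatter, as does a 1.2-fold higher number from compound 2 to compound 3 (0.07 log units; within the scatter). Compound 4 `O=C(O)c1cn(Cc2ccc(F)cc2)c2ccc(Cc3cccc(Cl)c3F)c(O)c2c1=O` differs from compound 1 by 4-fluorobenzyl in place of 1-(hydroxymethyl)-2-methylpropyl on an aromatic nitrogen. The two measured steps that exchange the same 1-(hydroxymethyl)-2-methylpropyl group on an aromatic nitleft only small changes, so the expected step is a 1.4-fold lower number from compound 1 to compound 4 (0.14 log units; within the scatter), nothing beyond the scatter. Compound 4 is therefore estimated at 90000 nM, with a range from 40000 nM to 200000 nM.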

Compound 4, half-maximal cytotoxic concentration: 65800 nM
For compound 4 the middle estimate is 1.4-fold (0.14 log units) above the measured one; the measured number falls inside the stated range.
By their numbers in this assay, from the lowest: compounds 4, 2, 3 and 1 (each within the scatter of the next).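

Reading this assay at the aromatic nitrogen, the steps of a 1.9-fold lower number from compound 1 to compound 4 (0.28 log units; within the scatter) and a 1.3-fold lower number from compound 3 to compound 4 (0.11 log units; within the scatter) and a 1.1-fold lower number from compound 2 to compound 4 (0.04 log units; within the scatter) all stay within the scatter. A benzyl group thus joins the directly attached phenyl groups and the open-chain 1-(hydroxymethyl)-2-methylpropyl group, and the read-out separates none of them at this position. Neither the 4-fluorobenzyl group's lack of hydrogen-bond donors nor its extra heavy atoms moved the number beyond the scatter. Whether an amine or a carboxylic acid on this nitrogen substituent would do so stays open, and no evidence here gives a reason for this sameness.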